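The source may hold more compounds than are shown below. What is called first, only, known or untested is meant among the compounds shown, and "the series" means these compounds.

Compound 1 `CCCCOC(=O)Nc1cc2nc(C3CCCCC3)[nH]c2cc1N(C)C` and compound 2 `CN(C)c1cc2[nH]c(C3CCCCC3)nc2cc1NC(=O)c1cccc(Br)c1` share one core and differ only at the carbonyl carbon. In an ADME assay on Vero cells (Chlorocebus sabaeus) for cytotoxicity, read by resazurin assay, with a stated time of 3 days (a lower number here means a stronger inhibitor, a higher number a weaker inhibitor), compound 1 reaches only a limit, > 100 ug/mL. Compound 2 likewise gives only a limit in this assay, > 100 ug/mL. The step that the two limits leave unreadable from compound 1 to compound 2 is therefore unreadable, as the limit of > 100 ug/mL in this assay, at which 2 of the 2 values shown sit, shows. Compound 3 `CN(C)c1cc2[nH]c(C3CCCCC3)nc2cc1NC(=O)c1ccco1` carries furan-2-yl in place of 3-bromophenyl on a carbonyl carbon. Within the data shown here, no measured step bears on this change beyond the two limits, so no shift beyond the scatter is expected. Compound 3 is estimated at 100 ug/mL, with a range from 50 ug/mL to 200 ug/mL. The expected step of a number no higher from compound 2 to compound 3 (the limit leaves the size open) is thus nil.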

Compound 3, half-maximal inhibitory concentration: > 100 ug/mL
Compound 3 gave a limit, no number; the forecaster's own chance of this, stated with the estimate: 85%; the middle value sits exactly at the limit.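

Compound 3, like compound 1 and compound 2, gives only a limit, so no step among these three compounds can be read: the limit of > 100 ug/mL in this assay, at which 3 of the 3 values shown sit.

The compounds shown leave open whether butoxy, 3-bromophenyl or furan-2-yl on the carbonyl carbon changes the read-out at all.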